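The source may hold more compounds than are shown below. What is called first, only, known or untested is meant among the compounds shown, and "the series" means these compounds.

Compound 3 `NC1CCN(c2ccc3cc(NC(=O)CCc4ccc(C(F)(F)F)cc4)ccc3n2)C1` is one of three close relatives that share a core and differ only in the amine attached to an aromatic carbon of that core. In an assay on isolated protein for displacement of a labelled ligand from melanin-concentrating hormone receptor 1 (Homo sapiens) (a higher number here means a weaker inhibitor, a lower number a stronger inhibitor), compound 3 gives 12 nM, the highest number of the three. Compound 1 `O=C(CCc1ccc(C(F)(F)F)cc1)Nc1ccc2nc(N3CCC3)ccc2c1` gives 4 nM, and compound 2 `CN(c1ccc2cc(NC(=O)CCc3ccc(C(F)(F)F)cc3)ccc2n1)C1CCCC1` gives 2 nM. The steps to compound 3 were a 3.0-fold higher number from compound 1 to compound 3 (0.48 log units; beyond the scatter) and a 6.0-fold higher number from compound 2 to compound 3 (0.78 log units; beyond the scatter). Compound 4 `O=C(CCc1ccc(C(F)(F)F)cc1)Nc1ccc2nc(N3CC4CCC3C4)ccc2c1` changes this spot once more: a group of 7 heavy atoms (6 carbon, 1 nitrogen; one five-membered non-aromatic ring of carbon only, one five-membered non-aromatic ring with 1 hetero atom) in place of a group of 6 heavy atoms (4 carbon, 2 nitrogen; one five-membered non-aromatic ring with 1 hetero atom), on an aromatic carbon. The group that enters carries no hydrogen-bond donor and is built from carbon and one nitrogen, which brings compound 4 closer in character to compound 1 and compound 2 than to compound 3. The expected step is therefore a 3.0-fold lower number from compound 3 to compound 4 (0.48 log units; beyond the scatter). For compound 4 the estimate in this assay is 4 nM, with a range from 1.5 nM to 12 nM.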

Compound 4, half-maximal inhibitory concentration: 1 nM
For compound 4 the middle estimate is 4.0-fold (0.60 log units) above the measured one; measured number below the stated range.
By their numbers in this assay, from the lowest: compounds 4, 2 and 1 (each within the scatter of the next, the first and the last beyond it); then compound 3.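

A second ring in the amine is tolerated at this position in this assay: the group with two five-membered rings gives a 12-fold lower number from compound 3 to compound 4 (1.08 log units; beyond the scatter), the largest step in this set, and a 4.0-fold lower number from compound 1 to compound 4 (0.60 log units; beyond the scatter). Compared with the single-ring cyclopentyl(methyl)amino group, which has the same count of heavy atoms, it gives a 2.0-fold lower number from compound 2 to compound 4 (0.30 log units; within the scatter), so these two groups cannot be told apart here. Nothing shown explains these differences. As far as these compounds go, how a piperidin-1-yl or morpholin-4-yl group would behave at this position remains open, as does whether the free amine of compound 3 accounts for its higher number.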